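Permeability across the series: from compound 3 to compound 4

The compounds below may be only part of what the source reports. "The series", "measured", "known", "first", "only" and "open" are said of these compounds alone.

Three members of this series have been measured in an ADME assay for permeability, using PAMPA, with a stated time of 30 min, at pH 7.4; on this read-out higher numbers stand for higher permeability and lower numbers for lower permeability. Compound 1 `COc1cccc(CNCCCNc2ccnc3cc(Cc4ccccc4)ccc23)c1O` gives 23 10^-6 cm/s; compound 2 `COc1cccc(CNCCCNc2ccnc3cc(-c4ccccc4)ccc23)c1O` gives 237 10^-6 cm/s; compound 3 `COc1cccc(CNCCCNc2ccnc3cc(Cc4ccc(C#N)cc4)ccc23)c1O` gives 23 10^-6 cm/s. The measured steps: a 10-fold higher number from compound 1 to compound 2 (1.01 log units; beyond the scatter). no change at the digits printed from compound 1 to compound 3 (within the scatter). a 10-fold lower number from compound 2 to compound 3 (1.01 log units; beyond the scatter). Compound 3 thus stands level with compound 1, the two together holding the lowest number of the three, while compound 2 sits a large step above.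

Compound 4 `N#Cc1ccc(Cc2ccc3c(NCCCNCc4ccco4)ccnc3c2)cc1` differs from compound 3 in one place: furan-2-yl in place of 2-hydroxy-3-methoxyphenyl on a saturated chain carbon bound to an amine nitrogen. Within the data shown here, none of the measured steps bears directly on this: all three alter the group on the aromatic carbon of the shared core and leave the amine side untouched. The one lesson carried over is that a single change elsewhere in the series moved the read-out by a large step, so a sizeable shift here cannot be excluded. In the absence of a direct precedent, a modest upward step is expected, a 2.0-fold higher number from compound 3 to compound 4 (0.29 log units; within the scatter). Compound 4 is therefore estimated at about 45 10^-6 cm/s, with an expected range from 15 10^-6 cm/s to 130 10^-6 cm/s.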

Compound 4, apparent permeability: 23 10^-6 cm/s
Estimate against measurement, compound 4: 2.0-fold (0.29 log units) above; the measured number falls inside the stated range.
By their numbers in this assay, from the lowest: compounds 1, 3 and 4 (each within the scatter of the next); then compound 2.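

In this assay, furan-2-yl in place of 2-hydroxy-3-methoxyphenyl on a saturated chain carbon bound to an amine nitrogen gives no change at the digits printed from compound 3 to compound 4 (within the scatter), the only step shown at this position. The group that leaves has 9 heavy atoms and 1 hydrogen-bond donor and the group that enters has 5 heavy atoms and 0 hydrogen-bond donors, yet with 4-cyanobenzyl held on the shared core this difference does not register in the read-out. No measurement at hand accounts for this result.

From the compounds shown here alone, whether the same exchange holds with phenyl on the shared core, as in compound 2, remains open. Also open, going by these compounds, is how an aliphatic amine, a carboxylic acid or a longer chain would read at this position.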